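The source may report more compounds than this note shows. Statements on the series, on what has been measured and on what is new or still open speak of the compounds shown alone.

Compound 1 `CCOC(=O)Cc1sc(-c2ccccc2)nc1O`: 950 nM in an assay on HEK293 cells for inhibition of transient receptor potential cation channel subfamily M member 8 (Homo sapiens), read by FLIPR, with stated times of 5 min and 3 min; on this read-out higher numbers stand for weaker inhibition and lower numbers for stronger inhibition
Compound 2 `CCOC(=O)c1sc(-c2ccccc2)nc1N`: > 100000 nM, a limit of the assay, not a number
Compound 3 `CCN(C)C(=O)c1sc(-c2ccccc2)nc1O`: 6400 nM

Compound 3 holds the highest number among the two actual values; compound 1 sits below it by a 6.7-fold higher number from compound 1 to compound 3 (0.83 log units; beyond the scatter), a step that swaps the whole carbamoylmethyl side chain and so bears only partly on what follows. Compound 4 `CCOC(=O)c1sc(-c2ccccc2)nc1O` differs from compound 3 by ethoxy in place of ethyl(methyl)amino on a carbonyl carbon. With compound 1 carrying the ester at a lower number, the ester of compound 4 is expected to give a modestly lower number than compound 3 in this assay. Compound 4 is therefore estimated at 1800 nM, between 450 nM and 7000 nM, a step of a 3.6-fold lower number from compound 3 to compound 4 (0.55 log units; beyond the scatter).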

Compound 4, half-maximal inhibitory concentration: 32 nM
For compound 4 the middle estimate is 56-fold (1.75 log units) above the measured one, outside the stated range (below it).
By their numbers in this assay, from the lowest: compound 4; then compound 1; then compound 3. At a limit, above all of these: compound 2.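

In this assay, the group on this aromatic carbon proves highly sensitive to the change at the carbonyl carbon, with ethoxy in place of ethyl(methyl)amino giving a 200-fold lower number from compound 3 to compound 4 (2.30 log units; beyond the scatter). The ester's attachment matters too, since ethoxycarbonyl in place of (ethoxycarbonyl)methyl gives a 30-fold lower number from compound 1 to compound 4 (1.47 log units; beyond the scatter). Hydroxy in place of amino on an aromatic carbon gives an at least 3100-fold lower number from compound 2 to compound 4 (3.49 log units; beyond the scatter), but the starting value of that step is a limit of the assay and not a number: the limit of > 100000 nM in this assay, at which 1 of the 4 values shown sits.

Going by these compounds, whether a carboxylic acid or a longer chain such as propoxycarbonyl at this position would keep the number as low remains open.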